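A Branch Added to a Butyl Chain

This account rests on a few compounds, and the source may have more. Where it says the series, first, only, none or still open, it means among the compounds named here.

In a functional assay on MDA-MB-231 cells (Homo sapiens) for antiproliferative activity, read by sulforhodamine B assay (a lower number here means a stronger inhibitor of growth, a higher number a weaker inhibitor of growth), compound 3 `CCCCOc1cccc(O)c1C(=O)/C=C/c1ccc(O)cc1` gives > 30000 nM, which is a limit of the assay and not a number. Compound 2 `O=C(/C=C/c1ccc(O)cc1)c1c(O)cccc1OCCC1CCCCC1` gives > 30000 nM, also a limit. Compound 1 `CC(C)(C)CCOc1cccc(O)c1C(=O)/C=C/c1ccc(O)cc1` gives a true number, 2380 nM.

Compound 4 `CC(C)CCOc1cccc(O)c1C(=O)/C=C/c1ccc(O)cc1` differs from compound 3 as butyl to isopentyl: methyl in place of hydrogen on a saturated chain carbon bound to two saturated chain carbons. This takes the chain end part of the way towards the tert-butyl of compound 1. Within the data shown here, two measured steps bear on it: an at least 12-fold higher number from compound 1 to compound 3 (1.10 log units; beyond the scatter) and an at least 12-fold higher number from compound 1 to compound 2 (1.10 log units; beyond the scatter). Both are large, though compound 2 shows that a larger chain end does not always give a lower number. A moderate move towards stronger inhibition is expected, estimated as an at least 3.3-fold lower number from compound 3 to compound 4 (0.52 log units; beyond the scatter). For compound 4 the estimated value is 9000 nM, with an expected range of 3000 nM to 30000 nM.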

Compound 4, concentration for 50% growth inhibition: 10300 nM
Compound 4: the middle estimate sits 1.1-fold (0.06 log units) below what was measured; low and high end bracket the measured number.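

A single methyl on the butyl chain already registers, with an at least 2.9-fold lower number from compound 3 to compound 4 (0.46 log units; beyond the scatter) in this small series, and swapping a cyclohexyl end for isopropyl gives an at least 2.9-fold lower number from compound 2 to compound 4 (0.46 log units; beyond the scatter) as well. Removing one methyl from the tert-butyl end also costs activity, with a 4.3-fold higher number from compound 1 to compound 4 (0.64 log units; beyond the scatter) as the measured step, so the number falls as this chain end branches further, though compound 2 shows that a bigger end alone does not do it. The first two steps are minimum sizes, since both start from a limit: the limit of > 30000 nM in this assay, at which 2 of the 4 values shown sit.

On these data alone, whether branching itself matters, or only the shape of the whole chain, stays open. A longer chain ending in tert-butyl, or an amine at the chain end, would test this.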